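This account rests on a few compounds, and the source may have more. Where it says the series, first, only, none or still open, it means among the compounds named here.

Measured compounds:
- compound 1 `Cn1c(N2CCCC2)c(C#N)c2c(N)ncnc21`: 41 nM
- compound 2 `Cc1cn(C)nc1Nc1cc2c(c(N)n1)c(C#N)c(N1CCC[C@H]1C)n2C`: 63 nM

In an assay on isolated protein for binding affinity to Leucine-rich repeat serine/threonine-protein kinase 2 (Homo sapiens), read by TR-FRET and LanthaScreen, with a stated time of 2 h (on this read-out lower numbers stand for stronger inhibition and higher numbers for weaker inhibition), compound 1 gives 41 nM and compound 2 gives 63 nM. These two numbers lie within the usual scatter of each other, so neither compound can be set above the other. Compound 3 `Cn1c(-c2ccccc2)c(C#N)c2c(N)ncnc21` has not yet been measured. It differs from compound 1 in one place: phenyl in place of pyrrolidin-1-yl on an aromatic carbon. Going by the values given here, no measured pair shows a change of this kind, so the expectation rests on the structural change alone, and a modest weakening of binding is the likeliest outcome. For compound 3 the expected value is 80 nM, with a range from 20 nM to 320 nM, which corresponds to an expected step of a 2.0-fold higher number from compound 1 to compound 3 (0.29 log units; within the scatter).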

Compound 3, inhibition constant: 30 nM
Compound 3: the middle estimate sits 2.7-fold (0.43 log units) above what was measured; low and high end bracket the measured number.
By their numbers in this assay, from the lowest: compounds 3, 1 and 2 (each within the scatter of the next, the first and the last beyond it).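

In this assay, putting phenyl in place of pyrrolidin-1-yl on this aromatic carbon gives a 1.4-fold lower number from compound 1 to compound 3 (0.14 log units; within the scatter), so the two groups cannot be told apart here. The position therefore accepts a six-membered aromatic ring of carbon only as well as a five-membered non-aromatic ring with a nitrogen, and that nitrogen is not needed to keep binding in this range on this core. Still open, from the compounds shown here alone, is whether a phenyl carrying an amine or a carboxylic acid, or an open chain such as ethyl, would fit as well. No data at hand give a reason for the match between these two groups.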